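A few compounds are considered here, and "the series" means these few. Any claim that something is new, unique, unknown or untested is made for them only; others in the source may bear on it.

Of the compounds shown here, two that share one core have been tested in a functional assay on L1210 cells (Mus musculus) for inhibition; on this read-out lower numbers stand for stronger inhibition and higher numbers for weaker inhibition. Compound 1 `C/C(=C\COC(=O)NC(C)(C)C)C1=CC(=O)C(C)(C)O1` gives 4.1 ug/mL in this assay. Compound 2 `C/C(=C\C=C/C1CCCCC1)C1=CC(=O)C(C)(C)O1` gives 23 ug/mL in this assay. Of these two numbers, compound 1 has the lower one, and the gap to compound 2 lies beyond the usual scatter of repeated measurements. For the measured compounds named here, the two structures differ in more than one place, so no single step between them can be read off.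

Compound 3 `C/C(=C\COC(=O)NCc1ccccc1)C1=CC(=O)C(C)(C)O1` is compound 1 with one change: benzyl in place of tert-butyl on an amide-type nitrogen. Going by the values given here, both the group that leaves and the group that enters carry no hydrogen-bond donors or acceptors, and no measured pair shows what this swap does, so the expectation rests on compound 1 alone. The step from compound 1 to compound 3 is expected to be a 1.2-fold lower number from compound 1 to compound 3 (0.07 log units; within the scatter), in other words no change beyond the scatter, with a slight lean towards a lower number. Compound 3 is therefore expected to give about 3.5 ug/mL in this assay, with a likely range from 1.2 ug/mL to 10 ug/mL.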

Compound 3, half-maximal inhibitory concentration: 4.7 ug/mL
Compound 3: middle estimate off by 1.3-fold (0.13 log units), on the low side, within the range that was stated.
By their numbers in this assay, from the lowest: compounds 1 and 3 (each within the scatter of the next); then compound 2.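

Swapping the group on the amide-type nitrogen gives the first direct reading at this position: in this assay, benzyl in place of tert-butyl amounts to a 1.1-fold higher number from compound 1 to compound 3 (0.06 log units; within the scatter), so the two compounds cannot be told apart on this read-out. The entering group carries 7 heavy atoms and a six-membered aromatic ring, whereas tert-butyl carries 4 heavy atoms and no ring, yet for this pair the change leaves the number within the scatter. Nothing available here accounts for this level result, so it stands as an observation without an explanation.

On these data alone, whether an amine, a carboxylic acid or a longer alkyl chain on this nitrogen would also leave the number in the same range stays open, and this single pair cannot show how far the tolerance extends. Compound 2 differs from compound 1 in more than one place, so the gap between their numbers still cannot be tied to any single structural change.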